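Removing a free hydroxy in a growth-inhibiting series

This account rests on a few compounds, and the source may have more. Where it says the series, first, only, none or still open, it means among the compounds named here.

Measured in a functional assay on NCI-H520 cells (Homo sapiens) for cytotoxicity; a higher number here means a weaker inhibitor of growth, a lower number a stronger inhibitor of growth
Compound 1 `CSc1ccc(C2=C(c3ccc(O)c(O)c3)C(=O)N3CCCC3C2)cc1` gives 60000 nM
Compound 2 `COc1ccc(C2=C(c3ccc(SC)cc3)CC3CCCN3C2=O)cc1` gives 800 nM
Compound 3 `CSc1ccc(C2=C(c3ccc(O)cc3)C(=O)N3CCCC3C2)cc1` gives > 100000 nM (a limit of the assay)

Compound 3 stands at a limit of the assay and has no number (> 100000 nM). Compound 4 `CSc1ccc(C2=C(c3ccc(SC)cc3)C(=O)N3CCCC3C2)cc1` differs from it by methylsulfanyl in place of hydroxy on an aromatic carbon, para to a large group (methylsulfanyl in place of hydroxy on an aromatic carbon). Two large measured steps bear on this change. The closer one is an at least 120-fold higher number from compound 2 to compound 3 (2.09 log units; beyond the scatter), where hydrogen takes the place of methyl on that oxygen. The other is a 75-fold lower number from compound 1 to compound 2 (1.88 log units; beyond the scatter), where 4-methoxyphenyl takes the place of 3,4-dihydroxyphenyl. The third step, an at least 1.6-fold higher number from compound 1 to compound 3 (0.22 log units; that floor lies within the scatter), has a floor within the scatter and adds little. Among the measured compounds shown here, no measured step brings methylsulfanyl into this place, so the expectation is carried over from the methoxy case. A large move to a lower number is therefore expected, an estimated at least 66-fold lower number from compound 3 to compound 4 (1.82 log units; beyond the scatter). Compound 4 is estimated at 1500 nM in this assay (expected range 300 nM to 10000 nM).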

Compound 4, concentration for 50% growth inhibition: 15000 nM
Estimate against measurement, compound 4: 10-fold (1.00 log units) below, outside the stated range (above it).
By their numbers in this assay, from the lowest: compound 2; then compound 4; then compound 1. At a limit, above all of these: compound 3.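

In this assay, methylsulfanyl at this place, para to a large group, gives a clearly lower number than hydroxy, with an at least 6.6-fold lower number from compound 3 to compound 4 (0.82 log units; beyond the scatter). It is no match for methoxy, however, with a 19-fold higher number from compound 2 to compound 4 (1.27 log units; beyond the scatter), and the change from 3,4-dihydroxyphenyl to 4-(methylsulfanyl)phenyl gives only a 4.0-fold lower number from compound 1 to compound 4 (0.60 log units; beyond the scatter). Compound 3 stands at a limit, so the first of these steps is only a floor: the limit of > 100000 nM in this assay, at which 1 of the 4 values shown sits.

The compounds shown leave open whether an amine or an ethoxy group at this place would come nearer to methoxy or to methylsulfanyl. They also leave open how large the step from hydroxy to methylsulfanyl really is.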